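Trading a Side Chain for a Cyano Group

This account rests on a few compounds, and the source may have more. Where it says the series, first, only, none or still open, it means among the compounds named here.

Measured so far:
compound 1 `CCOc1cc(=O)oc2cc(OCc3cccc(F)c3)ccc12`: 25%
compound 2 `CNC(=O)COc1cc(=O)oc2cc(OCc3cccc(Cl)c3)ccc12`: 11%

Both compounds were tested in an assay on isolated protein (strain Sprague-Dawley) for inhibition of Amine oxidase [flavin-containing] A (Rattus norvegicus), read by spectrophotometry, with a stated time of 5 min, tested at 10 uM; on this read-out lower numbers stand for less inhibition and higher numbers for more inhibition at the one concentration tested (going by the name of the read-out). In this assay compound 1 gives 25%, and in the same this assay compound 2 gives 11%. Compound 2 therefore stands lowest of the two numbers, and its nearest neighbour, compound 1, lies higher by an amount beyond the usual scatter. The two compounds differ in more than one place, so nothing can be read from this pair about any single change.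

Compound 3 `N#Cc1cc(=O)oc2cc(OCc3cccc(Cl)c3)ccc12` is the next compound to be measured. It keeps the core and the substituted benzyl ether of compound 2 and differs from it in one place: cyano in place of (methylcarbamoyl)methoxy on an aromatic carbon.

Within the data shown here, no measured pair shows this change, so there is no basis for a direction. The expectation is that the step from compound 2 to compound 3 in this assay stays within the scatter, giving a number 7 percentage points higher from compound 2 to compound 3 (within the scatter). Compound 3 is accordingly estimated at 18%, expected to fall between 0% and 40%.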

Compound 3, a percentage reported as inhibition, at one concentration (the size of the read-out at that concentration, not a potency): 23%
Compound 3: middle estimate off by 5 percentage points, on the low side; the range from low to high includes it.
By their numbers in this assay, from the lowest: compound 2; then compounds 3 and 1 (each within the scatter of the next).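

Swapping (methylcarbamoyl)methoxy for cyano, with the rest of the molecule unchanged, gives a number 12 percentage points higher from compound 2 to compound 3 (beyond the scatter) in this assay, and this is the first single-place comparison in the series. At this aromatic carbon, opposite the ring oxygen, the longer chain with its amide hydrogen is therefore not needed for the inhibition seen at the one concentration tested, since the much smaller cyano, with no hydrogen-bond donor, gives the higher number. Nothing measured here gives a reason for this rise.

On these data alone, a single step cannot separate the effect of losing the chain from the effect of gaining cyano, so it stays open whether a plain hydrogen, a methyl group or an amine at this position would read like compound 2 or like compound 3. As far as these compounds go, it is also open whether the same swap would give a similar step on a core carrying the fluorobenzyl ether of compound 1, or whether a carboxylic acid at the end of a longer chain would change the picture.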